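Extending the Ether Chain: From Compound 3 to Compound 4

This account rests on a few compounds, and the source may have more. Where it says the series, first, only, none or still open, it means among the compounds named here.

Three measured compounds share one core and differ only in the group carried on the ether chain. Compound 1 `[O-][n+]1nc(NCOCc2ccc(Cl)cc2)[n+]([O-])c2ccccc21` gives 5760 nM in a functional assay on PC-3 cells (Homo sapiens) for cytotoxicity, read by MTT assay, with a stated time of 72 h; on this read-out lower numbers stand for stronger inhibition and higher numbers for weaker inhibition. Compound 2 `[O-][n+]1nc(NCOCc2ccccc2)[n+]([O-])c2ccccc21` gives 13400 nM in this assay, and compound 3 `CCCOCNc1n[n+]([O-])c2ccccc2[n+]1[O-]` gives 14200 nM. Compound 3 thus has the highest of the three numbers; its gap to compound 2 is within the scatter, while a 2.5-fold higher number from compound 1 to compound 3 (0.39 log units; beyond the scatter) is a modest step beyond it.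

Compound 4 `CC(C)CCOCNc1n[n+]([O-])c2ccccc2[n+]1[O-]` has not yet been measured. It differs from compound 3 by isopropyl in place of methyl on a saturated chain carbon, two bonds along the chain from an oxygen on a saturated carbon, so the propyl chain becomes an isopentyl chain. For the measured compounds named here, no measured step alters the chain at this place; the nearest comparisons are a 1.1-fold higher number from compound 2 to compound 3 (0.03 log units; within the scatter) and a 2.5-fold higher number from compound 1 to compound 3 (0.39 log units; beyond the scatter), which show that exchanging the group on the ether oxygen shifts the number little or only moderately. For compound 4 a step within the scatter is therefore expected, a 1.3-fold lower number from compound 3 to compound 4 (0.11 log units; within the scatter). Compound 4 is estimated at 11000 nM, with a likely range from 4000 nM to 30000 nM.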

Compound 4, half-maximal inhibitory concentration: 11100 nM
Compound 4: the middle estimate sits 1.0-fold (0.00 log units) below what was measured, and the stated range covers the measured number.
By their numbers in this assay, from the lowest: compounds 1, 4, 2 and 3 (each within the scatter of the next, the first and the last beyond it).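

In this assay, for the compounds shown here, the first change at this place on the chain, from propyl to isopentyl, gives a 1.3-fold lower number from compound 3 to compound 4 (0.11 log units; within the scatter), so this added branched length does not move the number beyond the scatter. The isopentyl chain also cannot be told apart from the benzyl group, with a 1.2-fold lower number from compound 2 to compound 4 (0.08 log units; within the scatter), and the 4-chlorobenzyl group gives a 1.9-fold higher number from compound 1 to compound 4 (0.28 log units; within the scatter), so compound 4 stays within the scatter of compound 1, although compound 3 lies beyond it. Nothing further is available to explain these steps.

Still open, on these data alone, is whether a longer chain such as octyl, or an amine or a carboxylic acid at the end of the chain, would shift the number beyond the scatter. Also open, as far as these compounds go, is how a fluoro or methoxy group would compare with the chloro on the aromatic ring.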